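Working notes: ester substituent variation toward compound 4

This account rests on a few compounds, and the source may have more. Where it says the series, first, only, none or still open, it means among the compounds named here.

Compound 1 `Cc1ccccc1C(=O)OC(CCN(C)C)c1ccc(Cl)cc1` gives 1700 nM in an assay on NIH3T3 cells with Urotensin-2 receptor (Homo sapiens) as the target; on this read-out higher numbers stand for an effect only at larger amounts of compound and lower numbers for an effect already at smaller amounts. Compound 2 `COc1ccc(C(=O)OC(CCN(C)C)c2ccc(Cl)cc2)cc1` gives 2190 nM in this assay, and compound 3 `Cc1ccsc1C(=O)OC(CCN(C)C)c1ccc(Cl)cc1` gives 2510 nM in this assay. Compound 3 has the highest of the three numbers, but both gaps are within the scatter: a 1.5-fold higher number from compound 1 to compound 3 (0.17 log units; within the scatter) and a 1.1-fold higher number from compound 2 to compound 3 (0.06 log units; within the scatter). The remaining step, a 1.3-fold higher number from compound 1 to compound 2 (0.11 log units; within the scatter), is likewise within the scatter, so none of the three groups on the carbonyl carbon stands apart on these data.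

Compound 4 `CCc1ccccc1C(=O)OC(CCN(C)C)c1ccc(Cl)cc1` is not yet measured. The change is 2-ethylphenyl in place of 3-methylthiophen-2-yl on a carbonyl carbon. The step that bears on it most directly is a 1.5-fold higher number from compound 1 to compound 3 (0.17 log units; within the scatter), run in reverse, as the 2-ethylphenyl of compound 4 is the closest relative of the 2-methylphenyl of compound 1 among the measured groups. Because a 1.5-fold higher number from compound 1 to compound 3 (0.17 log units; within the scatter) was itself within the scatter, the expected step for compound 4 is a 1.4-fold lower number from compound 3 to compound 4 (0.14 log units; within the scatter), with no shift beyond the scatter. The estimate for compound 4 in this assay is 1800 nM, with a range from 800 nM to 4000 nM.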

Compound 4, half-maximal effective concentration: 1290 nM
The estimate for compound 4 lay 1.4-fold (0.14 log units) above the measured number; the range from low to high includes it.
By their numbers in this assay, from the lowest: compounds 4, 1, 2 and 3 (each within the scatter of the next).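

Across the group on the carbonyl carbon, 2-ethylphenyl stays within the scatter of every earlier compound in this assay (a 1.9-fold lower number from compound 3 to compound 4 (0.29 log units; within the scatter); a 1.7-fold lower number from compound 2 to compound 4 (0.23 log units; within the scatter); a 1.3-fold lower number from compound 1 to compound 4 (0.12 log units; within the scatter)), so a six-membered aromatic ring of carbon only, with no hydrogen-bond acceptor, stands in for the five-membered aromatic ring with one hetero atom without a step beyond the scatter. The added methyl on the saturated chain carbon also gives no step beyond the scatter (a 1.3-fold lower number from compound 1 to compound 4 (0.12 log units; within the scatter)), so the series still shows no group at this position that stands apart. The data offer no explanation for how closely these groups lie together.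

From the compounds shown here alone, whether a longer chain such as 2-propylphenyl, or a ring bearing an amine or a carboxylic acid, would move the number beyond the scatter remains open. Going by these compounds, the effect of changes elsewhere on the shared core also remains open.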